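Benzofuran to phenyl on the shared core

The source may hold more compounds than are shown below. What is called first, only, known or untested is meant among the compounds shown, and "the series" means these compounds.

In a functional assay on HCT-116 cells (Homo sapiens), read by MTT assay, with a stated time of 72 h (a lower number here means a stronger inhibitor, a higher number a weaker inhibitor), compound 2 `Cc1nc(N)c2c(-c3cc4ccccc4o3)cn([C@@H]3O[C@H](CO)[C@@H](O)[C@H]3O)c2n1` gives 13100 nM. Compound 1 `Nc1nc(N)c2c(-c3cc4ccccc4o3)cn([C@@H]3O[C@H](CO)[C@@H](O)[C@H]3O)c2n1` gives 14000 nM in this assay. The single-point step between them, a 1.1-fold lower number from compound 1 to compound 2 (0.03 log units; within the scatter), is within the scatter, so compound 2 and compound 1 stand together and neither can be set apart. Compound 3 `Cc1ncnc2c1c(-c1ccoc1)cn2[C@@H]1O[C@H](CO)[C@@H](O)[C@H]1O` returns only a limit in this assay, > 20000 nM. That value sits at the limit of > 20000 nM in this assay, at which 1 of the 3 values shown sits. Within the data shown here, compound 3 differs from compound 2 in more than one place, so no step is drawn from it. Compound 4 `Cc1nc(N)c2c(-c3ccccc3)cn([C@@H]3O[C@H](CO)[C@@H](O)[C@H]3O)c2n1` is not yet measured. The change is phenyl in place of 1-benzofuran-2-yl on an aromatic carbon. Among the measured compounds shown here, no measured step touches this ring; the one step on record concerns a substituent elsewhere on the shared core. The direction therefore rests on nothing measured, and the limit at the weak end of the series truncates what can be seen there. Compound 4 is expected at 18000 nM, with a range from 7000 nM to 45000 nM. This amounts to an expected 1.4-fold higher number from compound 2 to compound 4 (0.14 log units; within the scatter). A real chance remains that only a limit is reported.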

Compound 4, half-maximal inhibitory concentration: > 20000 nM
Compound 4: a limit, no number; the forecaster's own chance of this, stated with the estimate: 45%; at least 1.1-fold (0.04 log units) between middle value and limit.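

Phenyl in place of 1-benzofuran-2-yl is the first change read at this position, two ring bonds from the ring nitrogen, and it gives an at least 1.5-fold higher number from compound 2 to compound 4 (0.18 log units; that floor lies within the scatter). That floor establishes no loss, but phenyl on the shared core brings no measurable gain over the 1-benzofuran-2-yl of compound 2. The true size of the step cannot be read because compound 4 returns a limit and not a number: the limit of > 20000 nM in this assay, at which 2 of the 4 values shown sit.

Still open, as far as these compounds go, is whether phenyl bearing an amine or a carboxylic acid would give a number in this assay rather than a limit. Also open, from the compounds shown here alone, is whether methyl and amino on the shared core, which stand together in compound 1 and compound 2, would still do so with phenyl at this position.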